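Solubility of an oxazolidinone series: from an ester to a sulfonamide

The compounds below may be only part of what the source reports. "The series", "measured", "known", "first", "only" and "open" are said of these compounds alone.

Compound 2, `COC(=O)CC1CCN(C[C@H]2CN(c3ccc(-n4cc(-c5ccccn5)cn4)c(F)c3)C(=O)O2)CC1`, is the reference point here. In a physicochemical assay for solubility, read by HPLC, with a stated time of 24 h (on this read-out higher numbers stand for higher solubility and lower numbers for lower solubility), compound 2 gives 92100 nM, which is the highest of the two plain numbers shown. Compound 1, `O=C1O[C@@H](CO)CN1c1ccc(-n2cc(-c3ccccn3)cn2)c(F)c1`, is the nearest: in this assay compound 1 gives 56400 nM, and the step is a 1.6-fold higher number from compound 1 to compound 2 (0.21 log units; within the scatter). Compound 3, `O=C(OC[C@H]1CN(c2ccc(-n3cc(-c4ccccn4)cn3)c(F)c2)C(=O)O1)c1ccccc1`, carries a benzoyl on an oxygen on a saturated carbon. For compound 3 the read-out in this assay is a limit of the assay, <= 65400 nM. The step is therefore an at least 1.4-fold lower number from compound 2 to compound 3 (0.14 log units; that floor lies within the scatter), and the limit line is the limit of <= 65400 nM in this assay, at which 1 of the 3 values shown sits.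

Compound 4, `CS(=O)(=O)NC[C@H]1CN(c2ccc(-n3cc(-c4ccccn4)cn3)c(F)c2)C(=O)O1`, is the new member. Its change from compound 2 is methanesulfonamido in place of 4-((methoxycarbonyl)methyl)piperidin-1-yl on a saturated chain carbon bound to a saturated ring carbon. Both steps that alter the same position, a 1.6-fold higher number from compound 1 to compound 2 (0.21 log units; within the scatter) and an at least 1.4-fold lower number from compound 2 to compound 3 (0.14 log units; that floor lies within the scatter), stayed within the scatter, so no step beyond the scatter is expected here either, if anything a slight lowering. The expected step is a 1.3-fold lower number from compound 2 to compound 4 (0.12 log units; within the scatter). Compound 4 is estimated at 70000 nM in this assay, with a range from 30000 nM to 150000 nM.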

Compound 4, solubility: 2300 nM
Compound 4: the middle estimate sits 30-fold (1.48 log units) above what was measured; the measured number lies below the stated range.
By their numbers in this assay, from the lowest: compound 4; then compounds 1 and 2 (each within the scatter of the next).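

In this assay, the position on a saturated chain carbon bound to a saturated ring carbon now shows a large response to the group it carries: there is a 40-fold lower number from compound 2 to compound 4 (1.60 log units; beyond the scatter) and a 25-fold lower number from compound 1 to compound 4 (1.39 log units; beyond the scatter), whereas a 1.6-fold higher number from compound 1 to compound 2 (0.21 log units; within the scatter) gave no sign of this. Hydroxy and 4-((methoxycarbonyl)methyl)piperidin-1-yl, so unlike in size, thus lie within the scatter of each other, while methanesulfonamido stands clearly apart from both. The read-out of compound 3 is a limit of the assay, and its step to compound 4 cannot be read: the limit of <= 65400 nM in this assay, at which 1 of the 4 values shown sits.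

The compounds shown do not tell which part of the methanesulfonamido goes with the lower number. As far as these compounds go, whether an acetamido group or a primary amine on the same carbon would fall with compound 4 or with compounds 1 and 2 remains open.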